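Swapping the ring oxygen for sulfur in a peptidase assay series

The source may hold more compounds than are shown below. What is called first, only, known or untested is meant among the compounds shown, and "the series" means these compounds.

Two compounds share one core and differ only in the ring bound to a carbonyl carbon. Compound 1 `C[C@@H]1N[C@H](C(=O)N2CCC[C@H]2C#N)C[C@@H]1C(=O)N1CCC1` carries an azetidin-1-yl there, and in an assay on the whole organism (plasma, strain Sprague-Dawley) for inhibition of Dipeptidyl peptidase 4 (Rattus norvegicus), with a stated time of 6 h, at a dose of 1 mg/kg by the oral route (a lower number here means less inhibition, a higher number more inhibition at the dose given (going by the name of the read-out)), compound 1 gives 94%. Compound 2 `C[C@@H]1N[C@H](C(=O)N2CCC[C@H]2C#N)C[C@@H]1C(=O)N1CCOCC1` carries a morpholin-4-yl instead, and in this assay compound 2 gives 94%. The step of no change at the digits printed from compound 1 to compound 2 (within the scatter) shows that this exchange left the read-out where it was. Compound 2 therefore stands level with compound 1, with no difference that the scatter could not explain.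

Compound 3 `C[C@@H]1N[C@H](C(=O)N2CCC[C@H]2C#N)C[C@@H]1C(=O)N1CCSCC1` has not been measured. The change from compound 2 is thiomorpholin-4-yl in place of morpholin-4-yl on a carbonyl carbon. Within the data shown here, only the single step from compound 1 to compound 2 bears on it, and that step was flat, so a step of no size beyond the scatter is expected in this assay; the expected step is a number 1 percentage points lower from compound 2 to compound 3 (within the scatter). Compound 3 is estimated at 93%, within 84% to 98%.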

Compound 3, a percentage reported as inhibition, in the whole organism at one dose (the size of the read-out at that dose, not a potency): 92%
Estimate against measurement, compound 3: 1 percentage points above; the measured number falls inside the stated range.
By their numbers in this assay, from the lowest: compounds 3, 1 and 2 (each within the scatter of the next).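

Sulfur in place of the ring oxygen yields a number 2 percentage points lower from compound 2 to compound 3 (within the scatter) and thiomorpholin-4-yl in place of azetidin-1-yl yields a number 2 percentage points lower from compound 1 to compound 3 (within the scatter) in this assay for this group on a carbonyl carbon. Three different rings, azetidin-1-yl, morpholin-4-yl and thiomorpholin-4-yl, have now stood at this place with no step beyond the scatter, and exchanging oxygen for sulfur in the six-membered ring makes no difference that can be read here. Nothing at hand offers a reason for this flat result.

Still open, as far as these compounds go, is whether piperazin-1-yl, a ring carrying an amine, or a ring carrying a carboxylic acid would leave the read-out in this assay just as unmoved. These numbers give the size of the inhibition at one dose and one time, so they do not compare the compounds by potency.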